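Sulfonyl aryl swap in the shared core series

The source may report more compounds than this note shows. Statements on the series, on what has been measured and on what is new or still open speak of the compounds shown alone.

Compound 1 `COc1ccc(S(=O)(=O)c2cnc3ccc(C)cc3c2N2CCC(C)CC2)cc1` and compound 2 `CC1CCN(c2c(S(=O)(=O)c3cccc(Cl)c3)cnc3cc(Cl)ccc23)CC1` have both been run in an assay on isolated protein for displacement of a labelled ligand from metabotropic glutamate receptor 5 (Homo sapiens), with a stated time of 60 min, tested at 1 uM; a higher number here means more inhibition at the concentration tested (going by the name of the read-out), a lower number less inhibition. Compound 1 gives 62%, the lowest of the two numbers, while compound 2 gives 92%, a gap beyond the usual scatter. Going by the values given here, no pair differing in one place has been measured, so no single step size is yet known.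

Compound 3 `Cc1ccc2ncc(S(=O)(=O)c3cc(Cl)cc(Cl)c3)c(N3CCC(C)CC3)c2c1` has not been measured. It differs from compound 1 at one place: 3,5-dichlorophenyl in place of 4-methoxyphenyl on a sulfonyl sulfur. With only compound 2 as a second reference, the step from compound 1 to compound 3 in this assay is expected to be upward, on the order of a number 20 percentage points higher from compound 1 to compound 3 (beyond the scatter), though the scatter and the thin basis leave real room for a smaller move or none at all. For compound 3 the expected value in this assay is 82%, within a range from 62% to 97%.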

Compound 3, a percentage reported as inhibition, at one concentration (the size of the read-out at that concentration, not a potency): 75%
The estimate for compound 3 lay 7 percentage points above the measured number; the measured number falls inside the stated range.
By their numbers in this assay, from the lowest: compound 1; then compound 3; then compound 2.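

With the rest of compound 1 unchanged, 3,5-dichlorophenyl in place of 4-methoxyphenyl on a sulfonyl sulfur gives a number 13 percentage points higher from compound 1 to compound 3 (beyond the scatter) in this assay, a modest step. Going by these compounds alone, this is the first change that can be read at a single place, and it shows that the aryl group on the sulfonyl sulfur alone can shift the read-out beyond the scatter. Nothing on hand accounts for the size or direction of this step.

Compound 2 differs from both compound 1 and compound 3 in more than one place, so steps to it cannot be read. Still open, on these data alone, is whether the step needs both chlorines or merely the loss of the 4-methoxyphenyl, which a plain phenyl or a cyclohexyl on the same sulfur would help to separate.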